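A few compounds are considered here, and "the series" means these few. Any claim that something is new, unique, unknown or untested is made for them only; others in the source may bear on it.

In a functional assay on DLD-1 cells (Homo sapiens) for antiproliferative activity, read by CellTiter-Glo, with a stated time of 72 h (on this read-out lower numbers stand for stronger inhibition and higher numbers for weaker inhibition), compound 1 `CC1CCN(C2CCN(S(=O)(=O)c3cccc(-c4ccccc4C(F)(F)F)c3)CC2)CC1` gives 10 nM, compound 2 `COc1ccccc1-c1ccc(S(=O)(=O)N2CCC(N3CCC(C)CC3)CC2)cc1` gives 26 nM, and compound 3 `CC1CCN(C2CCN(S(=O)(=O)c3ccccc3-c3ccc(C(F)(F)F)cc3)CC2)CC1` gives 122 nM. Compound 3 therefore stands at the highest of the three numbers, and its gaps to compound 2 and to compound 1 both lie beyond the usual scatter. Compound 4 `CC1CCN(C2CCN(S(=O)(=O)c3ccccc3Br)CC2)CC1` has not yet been measured. It differs from compound 3 in one place: bromo in place of 4-(trifluoromethyl)phenyl on an aromatic carbon. Among the compounds with values here, no pair of measured compounds shows a step of this kind, so the expectation rests on compound 3 alone. The step of a 9.8-fold higher number from compound 3 to compound 4 (0.99 log units; beyond the scatter) is expected to weaken inhibition by more than the scatter. For compound 4 the estimate is 1200 nM, with a range from 250 nM to 6000 nM.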

Compound 4, half-maximal inhibitory concentration: 3 nM
Compound 4: the middle estimate sits 400-fold (2.60 log units) above what was measured, and the stated range ends above it.
By their numbers in this assay, from the lowest: compound 4; then compound 1; then compound 2; then compound 3.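

In this assay, putting bromo in place of 4-(trifluoromethyl)phenyl on this aromatic carbon, ortho to a large group, gives a 41-fold lower number from compound 3 to compound 4 (1.61 log units; beyond the scatter). The second aromatic ring is therefore not needed at this position, and a single bromine atom does far better here than the larger group it replaces. Nothing measured here accounts for the size of this step.

On these data alone, how chloro, methyl or a nitrile would fare on this carbon stays open, and so does whether bromo would give a similar number on another carbon of the ring.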